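The source may report more compounds than this note shows. Statements on the series, on what has been measured and on what is new or still open speak of the compounds shown alone.

Measured so far:
- compound 1 `Cn1ccc2cc(Nc3ncc(F)c(-c4cnn(CCC#N)c4)n3)ccc21`, which in an ADME assay on microsomes from liver (Homo sapiens) for metabolic stability (on this read-out lower numbers stand for slow clearance and higher numbers for fast clearance), gives 182 mL.min-1.g-1
- compound 2 `N#CCCn1cc(-c2nc(Nc3ccc4c(ccn4S(=O)(=O)C(F)(F)F)c3)ncc2F)cn1`, which in this assay gives 11.4 mL.min-1.g-1

Within the data shown here, of the two numbers in hand, compound 2 stands at the lower one, with compound 1 the only neighbour; the single measured step, a 16-fold lower number from compound 1 to compound 2 (1.20 log units; beyond the scatter), is large and beyond the scatter. Compound 3 `N#CCCn1cc(-c2nc(Nc3ccc4c(ccn4S(=O)(=O)c4ccc(C(F)(F)F)cc4)c3)ncc2F)cn1` differs from compound 2 in one place: 4-(trifluoromethyl)phenyl in place of trifluoromethyl on a sulfonyl sulfur. Among the measured compounds shown here, no measured step touches the group on the sulfonyl sulfur: the one step in hand concerns the group on the aromatic nitrogen, so it does not bear on this change, and the direction of the new step cannot be read from the data. An increase that may or may not pass beyond the scatter is therefore expected, and compound 3 is estimated in this assay at 25 mL.min-1.g-1, within a range of 8 mL.min-1.g-1 to 80 mL.min-1.g-1. The step from compound 2 to compound 3 is thus expected to be a 2.2-fold higher number from compound 2 to compound 3 (0.34 log units; beyond the scatter).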

Compound 3, intrinsic clearance in microsomes: 36.4 mL.min-1.g-1
Estimate against measurement, compound 3: 1.5-fold (0.16 log units) below, within the range that was stated.
By their numbers in this assay, from the lowest: compound 2; then compound 3; then compound 1.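

In this assay, the group on the sulfonyl sulfur proves able to shift the read-out: 4-(trifluoromethyl)phenyl in place of trifluoromethyl gives a 3.2-fold higher number from compound 2 to compound 3 (0.50 log units; beyond the scatter), a modest step that lies beyond the scatter. The earlier pair spoke only to the group on the aromatic nitrogen, whereas this pair shows that a substituent with an aromatic ring, in place of one with no ring, can sit on the sulfonyl sulfur with a moderate change in the number. Even so, compound 3 at 36.4 mL.min-1.g-1 stays on the low side of compound 1 at 182 mL.min-1.g-1, and no measurement at hand explains why the number rises from the trifluoromethyl to the aryl sulfonyl compound.

On these data alone, what remains open is whether the step comes with the aromatic ring itself or with the trifluoromethyl it carries, a question that an unsubstituted phenyl or a 4-methoxyphenyl on the sulfonyl sulfur would address. Also open is how a simple methyl or a dimethylamino group on that sulfur would compare with the two groups shown.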